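A few compounds are considered here, and "the series" means these few. Any claim that something is new, unique, unknown or untested is made for them only; others in the source may bear on it.

In a functional assay on K562 cells (Homo sapiens) for antiproliferative activity, with a stated time of 72 h (a lower number here means a stronger inhibitor, a higher number a weaker inhibitor), compound 1 `OC[C@H]1O[C@@H](n2cnc3c(NCc4ccc(Cl)c(Cl)c4)ncnc32)[C@H](O)[C@@H]1O` gives 10800 nM and compound 3 `OC[C@H]1O[C@@H](n2cnc3c(NCc4cccc(O)c4O)ncnc32)[C@H](O)[C@@H]1O` gives 25800 nM, the higher of these two numbers. Compound 2 `COc1ccc(CNc2ncnc3c2ncn3[C@@H]2O[C@H](CO)[C@@H](O)[C@H]2O)c(OC)c1` reads > 166000 nM, which is a limit of the assay. Compound 4 `OC[C@H]1O[C@@H](n2cnc3c(NCc4ccccc4OC(F)F)ncnc32)[C@H](O)[C@@H]1O` follows from compound 3 through (2-(difluoromethoxy)phenyl in place of 2,3-dihydroxyphenyl on a saturated chain carbon bound to a nitrogen on an aromatic ring). All measured steps fall at this same place, and they range from modest to large. The nearest analogy is compound 2, whose 2,4-dimethoxyphenyl also carries ether oxygen, and an at least 6.4-fold lower number from compound 2 to compound 3 (0.80 log units; beyond the scatter) suggests a higher number for compound 4. Against that, a 2.4-fold higher number from compound 1 to compound 3 (0.38 log units; beyond the scatter) shows that hydroxyls are not required, while an at least 15-fold higher number from compound 1 to compound 2 (1.18 log units; beyond the scatter) warns of a large loss. A modest rise is expected: a 2.3-fold higher number from compound 3 to compound 4 (0.37 log units; beyond the scatter). For compound 4 the estimated value is 60000 nM, with an expected range of 15000 nM to 166000 nM.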

Compound 4, half-maximal inhibitory concentration: > 166000 nM
Compound 4: no number, only a limit; the forecaster's own chance of this, stated with the estimate: 30%; middle value at least 2.7-fold (0.44 log units) away from the limit.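

In this assay, 2-(difluoromethoxy)phenyl at this place gives an at least 6.4-fold higher number from compound 3 to compound 4 (0.80 log units; beyond the scatter), and an at least 15-fold higher number from compound 1 to compound 4 (1.18 log units; beyond the scatter). Among the compounds shown, both phenyl groups with ether oxygen, in compound 2 and compound 4, now end at a limit, whereas the chloro and hydroxyl groups give numbers: the limit of > 166000 nM in this assay, at which 2 of the 4 values shown sit. The step between compound 2 and compound 4 cannot be read.

Going by these compounds, whether the loss follows the ether oxygen or the fluorine atoms stays open. On these data alone, how an unsubstituted phenyl, an amine or a carboxylic acid would read at this place also stays open.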